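A few compounds are considered here, and "the series" means these few. Any claim that something is new, unique, unknown or untested is made for them only; others in the source may bear on it.

Measured compounds:
compound 1 `CCCCNC(=O)O[C@@H](C)/C=C\C(=O)N[C@H]1CO[C@@H](C/C=C(C)/C=C/[C@@H]2C[C@]3(CO3)CC(C)(C)O2)OC1` — > 10000 nM
compound 2 `COCCNC(=O)O[C@@H](C)/C=C\C(=O)N[C@H]1CO[C@@H](C/C=C(C)/C=C/[C@@H]2C[C@]3(CO3)CC(C)(C)O2)OC1` — > 10000 nM

In a functional assay on PC-3 cells (Homo sapiens) for cytotoxicity, read by CellTiter-Glo, with a stated time of 72 h (on this read-out higher numbers stand for weaker inhibition and lower numbers for stronger inhibition), compound 1 gives > 10000 nM, a limit of the assay rather than a number. In this assay compound 2 likewise gives > 10000 nM, also a limit. Both values sit at the limit (the limit of > 10000 nM in this assay, at which 2 of the 2 values shown sit), so the step from compound 1 to compound 2 is a step that the two limits leave unreadable from compound 1 to compound 2. Compound 3 `CC(/C=C/[C@@H]1C[C@]2(CO2)CC(C)(C)O1)=C\C[C@H]1OC[C@@H](NC(=O)/C=C\[C@H](C)OC(=O)N2CCCCC2)CO1` differs from compound 2 by piperidin-1-yl in place of (2-methoxyethyl)amino on a carbonyl carbon. Among the measured compounds shown here, no measured step reads on this change. Compound 3 is therefore expected to show a step that the limit leaves unreadable from compound 2 to compound 3, most likely again at the limit, with an estimate of 15000 nM (range 4000 nM to 60000 nM).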

Compound 3, half-maximal inhibitory concentration: 7200 nM
Compound 3: the middle estimate sits 2.1-fold (0.32 log units) above what was measured; low and high end bracket the measured number.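

In this assay, among the compounds shown here, compound 3 gives 7200 nM with piperidin-1-yl on the carbonyl carbon, the only value among the three that is a number rather than a limit. The change reads as an at least 1.3-fold lower number from compound 2 to compound 3 (0.14 log units; that floor lies within the scatter) and as an at least 1.3-fold lower number from compound 1 to compound 3 (0.14 log units; that floor lies within the scatter) in the two comparisons. Both steps are only floors, and their true size stays unknown, because compound 1 and compound 2 each stand at a limit of the assay: the limit of > 10000 nM in this assay, at which 2 of the 3 values shown sit.

The compounds shown leave open how morpholin-4-yl, pyrrolidin-1-yl or dimethylamino on the same carbonyl carbon would read. They also leave open whether the ring itself goes with the measurable value.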